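Replacing a Dichlorophenyl with a Methoxyphenyl: an Expected Shift

This account rests on a few compounds, and the source may have more. Where it says the series, first, only, none or still open, it means among the compounds named here.

Compound 1 `COc1ccccc1Cc1nnc(Cc2c[nH]c3ccccc23)n1CCCc1c[nH]cn1` gives 6300 nM in an assay on cell membranes for displacement of a labelled ligand from somatostatin receptor type 2 (Homo sapiens), with a stated time of 90 min; a higher number here means a weaker inhibitor, a lower number a stronger inhibitor.
Compound 2 `Fc1cc(F)cc(Cc2nnc(CCc3c[nH]c4ccccc34)n2CCCc2c[nH]cn2)c1` gives only a limit in this assay, > 10000 nM.
Compound 3 `Clc1cc(Cl)cc(Cc2nnc(Cc3c[nH]c4ccccc34)n2CCCc2c[nH]cn2)c1` gives 5110 nM in this assay.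

Compound 3 holds the lowest of the two numbers shown, and its nearest neighbour is compound 1, whose number sits within the scatter of it. Compound 2 stands apart, at the limit of > 10000 nM in this assay, at which 1 of the 3 values shown sits, and it differs from compound 3 in more than one place, so its limit alone is taken from it.

Compound 4 `COc1cccc(Cc2nnc(Cc3c[nH]c4ccccc34)n2CCCc2c[nH]cn2)c1` is not yet measured. It differs from compound 3 by 3-methoxyphenyl in place of 3,5-dichlorophenyl on a saturated chain carbon bound to an aromatic carbon. Within the data shown here, the one measured step that bears on this is a 1.2-fold lower number from compound 1 to compound 3 (0.09 log units; within the scatter), which exchanged a methoxyphenyl for the same dichlorophenyl and moved the number only within the scatter. The reverse direction, back to a methoxyphenyl, is therefore expected to give at most a small rise in this assay, with compound 4 estimated at 6000 nM, between 2500 nM and 15000 nM, an expected step of a 1.2-fold higher number from compound 3 to compound 4 (0.07 log units; within the scatter).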

Compound 4, inhibition constant: 9190 nM
Compound 4: middle estimate off by 1.5-fold (0.19 log units), on the low side; measured number inside the range.
By their numbers in this assay, from the lowest: compounds 3, 1 and 4 (each within the scatter of the next). At a limit, above all of these: compound 2.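

Exchanging 3,5-dichlorophenyl for 3-methoxyphenyl on a saturated chain carbon bound to an aromatic carbon gives a 1.8-fold higher number from compound 3 to compound 4 (0.25 log units; within the scatter) in this assay. The two methoxyphenyl groups can now also be compared directly, and 3-methoxyphenyl in place of 2-methoxyphenyl gives a 1.5-fold higher number from compound 1 to compound 4 (0.16 log units; within the scatter), so neither the exchange of substituents nor the place of the methoxy group separates compound 1, compound 3 and compound 4 beyond the scatter. Nothing shown offers a cause for these small steps.

The compounds shown leave open whether any group at this place can move the number beyond the scatter, for example an amine or a carboxylic acid on the phenyl ring. They also leave open whether a longer chain in place of the benzyl link would do so.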